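Cutting the sulfur substituent of compound 3 to methyl

The source may hold more compounds than are shown below. What is called first, only, known or untested is meant among the compounds shown, and "the series" means these compounds.

Three compounds with a shared core, differing only in the group on sulfur, have been measured in a functional assay on HT cells (Homo sapiens) for antiproliferative activity, read by fluorescence, with a stated time of 72 h; a higher number here means a weaker inhibitor of growth, a lower number a stronger inhibitor of growth. Compound 1 `CC(C)c1n[nH]c2c(NCc3ccc(-c4ccccn4)cc3)nc(SCC(O)CO)nc12`, carrying 2,3-dihydroxypropyl, gives 21 nM. Compound 2 `CC(C)c1n[nH]c2c(NCc3ccc(-c4ccccn4)cc3)nc(SCC(O)CN3CCNCC3)nc12`, carrying 2-hydroxy-3-(piperazin-1-yl)propyl, gives 332 nM. Compound 3 `CC(C)c1n[nH]c2c(NCc3ccc(-c4ccccn4)cc3)nc(SC(CO)C(C)C)nc12`, carrying 1-(hydroxymethyl)-2-methylpropyl, gives 980 nM, the highest number of the three, with its steps to both others beyond the scatter.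

Compound 4 `CSc1nc(NCc2ccc(-c3ccccn3)cc2)c2[nH]nc(C(C)C)c2n1` has methyl in place of 1-(hydroxymethyl)-2-methylpropyl on a sulfur. Within the data shown here, no measured step makes this exact change, so the evidence is indirect. The relevant steps are those that alter the same sulfur substituent. The step of a 47-fold higher number from compound 1 to compound 3 (1.67 log units; beyond the scatter) is large, and the step of a 3.0-fold higher number from compound 2 to compound 3 (0.47 log units; beyond the scatter) is modest. The step of a 16-fold higher number from compound 1 to compound 2 (1.20 log units; beyond the scatter) shows that a change at the far end of the chain can also move the number widely. Both other substituents give lower numbers than compound 3, so a fall is more likely than a rise, but methyl matches neither of them, and only a modest shift is expected. The expected change is a 3.3-fold lower number from compound 3 to compound 4 (0.51 log units; beyond the scatter). Compound 4 is estimated at 300 nM, with an expected range from 60 nM to 1500 nM.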

Compound 4, concentration for 50% growth inhibition: 783 nM
Beside the measured number, compound 4's estimate is 2.6-fold (0.42 log units) below it; the range from low to high includes it.
By their numbers in this assay, from the lowest: compound 1; then compound 2; then compounds 4 and 3 (each within the scatter of the next).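

In this assay, methyl in place of 1-(hydroxymethyl)-2-methylpropyl on the sulfur gives a 1.3-fold lower number from compound 3 to compound 4 (0.10 log units; within the scatter), so the two compounds cannot be told apart here, even though the group that leaves has 6 heavy atoms, a hydrogen-bond donor and a hydrogen-bond acceptor. With methyl as a small reference group at this position, the other two substituents stand apart from it to very different degrees: 2-hydroxy-3-(piperazin-1-yl)propyl shows a modest step, a 2.4-fold higher number from compound 2 to compound 4 (0.37 log units; beyond the scatter), and 2,3-dihydroxypropyl a large one, a 37-fold higher number from compound 1 to compound 4 (1.57 log units; beyond the scatter). Nothing measured here accounts for these differences.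

The compounds shown leave open whether the low number of compound 1 needs both hydroxy groups of its chain, as a 2-hydroxyethyl or 3-hydroxypropyl group on the sulfur could show. They also leave open how a 2-aminoethyl group or a carboxylic acid at the end of a short chain on the sulfur would compare with the 2,3-dihydroxypropyl group of compound 1.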